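Hydrogen in place of methoxy on compound 1

The compounds below may be only part of what the source reports. "The series", "measured", "known", "first", "only" and "open" are said of these compounds alone.

In a functional assay on HuTu80 cells (Homo sapiens) for cytotoxicity, read by MTT assay, with a stated time of 72 h (on this read-out lower numbers stand for an effect already at smaller amounts and higher numbers for an effect only at larger amounts of compound), compound 1 (`COc1ccc(/C=C2\C(=O)N(c3c(Cl)cccc3Cl)c3ccccc32)cc1OC`) gives < 1 ug/mL as a limit and not a number. Compound 2 (`Cc1ccc2nc(Cl)c(/C=C3\C(=O)N(c4c(Cl)cccc4Cl)c4ccccc43)cc2c1C`) gives < 1 ug/mL in this assay and that too is a limit. Compound 1 therefore stands at the limit of < 1 ug/mL in this assay, at which 2 of the 2 values shown sit, and no exact value is known for it. Compound 3 (`COc1ccc(/C=C2\C(=O)N(c3c(Cl)cccc3Cl)c3ccccc32)cc1`) differs from compound 1 by hydrogen in place of methoxy on an aromatic carbon with hydrogen in place of methoxy on an aromatic carbon, ortho to a methoxy group. Within the data shown here, no measured step covers this change, and no shift beyond the scatter is expected in this assay and the expected step is a step that the limit leaves unreadable from compound 1 to compound 3 in size. For compound 3 the estimated value is 0.6 ug/mL with an expected range from 0.15 ug/mL to 2.5 ug/mL in this assay.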

Compound 3, concentration for half-maximal effect: > 100 ug/mL
Compound 3: no number, only a limit; the forecaster's own chance of this, stated with the estimate: 60%; at least 160-fold (2.22 log units) between middle value and limit.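

Hydrogen in place of methoxy on an aromatic carbon, ortho to a methoxy group, gives in this assay a step of an at least 100-fold higher number from compound 1 to compound 3 (2.00 log units; beyond the scatter). Compound 1 and compound 2 sat at one shared limit and could not show that this single position matters so strongly on the core of compound 1. Compound 3 ends at a limit and not at a number: the limit of > 100 ug/mL in this assay, at which 1 of the 3 values shown sits.

Going by these compounds, the true size of the step stays open. So does whether a hydroxy group, an amine or a fluorine at this place would keep the effect of the methoxy group.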